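A few compounds are considered here, and "the series" means these few. Any claim that something is new, unique, unknown or untested is made for them only; others in the source may bear on it.

Compound 1 `COc1ccc(NS(=O)(=O)/C=C/c2c(OC)cc(OC)cc2OC)cc1` gives 250 nM in a functional assay on BT-20 cells (Homo sapiens) for cytotoxicity, read by trypan blue exclusion, with a stated time of 96 h; on this read-out higher numbers stand for weaker inhibition of growth and lower numbers for stronger inhibition of growth
Compound 2 `COc1cc(OC)c(/C=C/S(=O)(=O)Nc2ccc(OC)c(O)c2)c(OC)c1` gives 250 nM in this assay

Compound 2 stands level with compound 1 at the digits shown, and compound 1 is its nearest neighbour. The next compound to test is compound 3 `COc1cc(OC)c(/C=C/S(=O)(=O)Nc2ccc(OC)c(N)c2)c(OC)c1`, reached by the change amino in place of hydroxy on an aromatic carbon on an aromatic carbon, ortho to a methoxy group and meta to a large group. Among the measured compounds shown here, only one measured step bears on it: no change at the digits printed from compound 1 to compound 2 (within the scatter) for hydroxy in place of hydrogen on an aromatic carbon. That step sets no size for amino in place of hydroxy, so the expectation is loose. A modest move toward stronger inhibition of growth is expected in this assay as a 2.5-fold lower number from compound 2 to compound 3 (0.40 log units; beyond the scatter) and no change beyond the scatter remains possible. For compound 3 the estimate is 100 nM with an expected range of 10 nM to 350 nM on this read-out.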

Compound 3, concentration for 50% growth inhibition: 8 nM
Compound 3: the middle estimate sits 13-fold (1.10 log units) above what was measured; measured number below the stated range.
By their numbers in this assay, from the lowest: compound 3; then compounds 1 and 2 (each within the scatter of the next).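

The position ortho to a methoxy group proves highly sensitive in this assay, and not to every replacement of hydrogen: for hydroxy in place of hydrogen the earlier pair showed no change at the digits printed from compound 1 to compound 2 (within the scatter) and so gave no sign of this. Amino in place of hydroxy gives a 31-fold lower number from compound 2 to compound 3 (1.49 log units; beyond the scatter) and amino in place of hydrogen gives a 31-fold lower number from compound 1 to compound 3 (1.49 log units; beyond the scatter) on the same scale, so both comparisons with the 3-amino-4-methoxyphenyl group agree in size. Of the three groups compared on this aromatic carbon, only amino stands apart, while hydrogen and hydroxy remain level.

On these data alone, whether a methylamino, acetamido or aminomethyl group at this position would match amino remains open. Nothing in the data at hand gives a reason for the gap between amino and hydroxy.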